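Methyl for Bromo on the Sulfonyl Aryl Ring

The compounds below may be only part of what the source reports. "The series", "measured", "known", "first", "only" and "open" are said of these compounds alone.

Measured compounds:
compound 1 `Cc1ccc(S(=O)(=O)/C(=C/c2ccc(C)s2)C(=O)c2ccc(Cl)cc2)cc1` gives 50000 nM
compound 2 `Cc1ccc(CS/C(=C/c2c(O)cc(O)cc2O)C(=O)c2ccc(Cl)cc2)cc1` gives 50000 nM
compound 3 `O=C(/C(=C\c1c(O)cc(O)cc1O)S(=O)(=O)c1ccc(Br)cc1)c1ccc(Cl)cc1` gives > 100000 nM

In a functional assay on DU-145 cells (Homo sapiens) for inhibition, read by trypan blue exclusion, with a stated time of 96 h (on this read-out lower numbers stand for stronger inhibition of growth and higher numbers for weaker inhibition of growth), compound 1 and compound 2 each give a number, while compound 3 gives only a limit of the assay, sitting at the limit of > 100000 nM in this assay, at which 1 of the 3 values shown sits. Compound 3 therefore stands at the weak end of the numbers shown. Compound 4 `Cc1ccc(S(=O)(=O)/C(=C/c2c(O)cc(O)cc2O)C(=O)c2ccc(Cl)cc2)cc1` differs from compound 3 by methyl in place of bromo on an aromatic carbon. Going by the values given here, the only measured step touching compound 3 is an at least 2.0-fold higher number from compound 2 to compound 3 (0.30 log units; that floor lies within the scatter), which alters the chain substituent rather than the aryl ring, and its floor lies within the scatter; no measured step exchanges methyl for bromo. Compound 1 shares the (4-methylphenyl)sulfonyl of compound 4 but on a different chain, so its value stands alone. In this assay compound 4 is expected to remain weak, with a step of a number no higher from compound 3 to compound 4 (the limit leaves the size open), estimated at 100000 nM within 40000 nM to 250000 nM.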

Compound 4, concentration for 50% growth inhibition: > 100000 nM
Compound 4: a limit, no number; the forecaster's own chance of this, stated with the estimate: 50%; the middle value sits exactly at the limit.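

In this assay compound 4 gives > 100000 nM, which is a limit of the assay and not a number. Methyl in place of bromo on this aromatic carbon, para to a large group, therefore gives a step that cannot be read, while the other two steps are an at least 2.0-fold higher number from compound 2 to compound 4 (0.30 log units; that floor lies within the scatter) and an at least 2.0-fold higher number from compound 1 to compound 4 (0.30 log units; that floor lies within the scatter). The limit now holds two of the compounds: the limit of > 100000 nM in this assay, at which 2 of the 4 values shown sit.

As far as these compounds go, how compound 3 and compound 4 truly stand relative to each other stays open. So does whether an amine or a carboxylic acid in place of the methyl on this ring would give a measurable number in this assay.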